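The compounds below may be only part of what the source reports. "The series", "measured", "known", "first", "only" and "open" are said of these compounds alone.

Compound 1 `COc1nc(-c2ccc(Cl)cc2)ccc1[C@@H](c1ccccc1)[C@@](O)(CCN(C)C)c1cccc2ccccc12` is the starting point. In a toxicity assay on Vero cells (Chlorocebus sabaeus) for cytotoxicity (on this read-out lower numbers stand for higher toxicity in this test and higher numbers for lower toxicity in this test), compound 1 gives > 50 ug/mL, which is a limit of the assay rather than a number. Its two close relatives are compound 2 `COc1nc(-c2cccc(F)c2)ccc1[C@@H](c1ccccc1)[C@@](O)(CCN(C)C)c1cccc2ccccc12` and compound 3 `COc1nc(-c2ccc(F)cc2)ccc1[C@@H](c1ccccc1)[C@@](O)(CCN(C)C)c1cccc2ccccc12`. In this assay compound 2 gives > 50 ug/mL, also a limit. In this assay compound 3 gives > 50 ug/mL, again a limit. The steps among them, a step that the two limits leave unreadable from compound 1 to compound 2, a step that the two limits leave unreadable from compound 1 to compound 3 and a step that the two limits leave unreadable from compound 2 to compound 3, therefore cannot be sized, since (the limit of > 50 ug/mL in this assay, at which 3 of the 3 values shown sit). Compound 4 `COc1nc(-c2ccc(C(F)(F)F)cc2)ccc1[C@@H](c1ccccc1)[C@@](O)(CCN(C)C)c1cccc2ccccc12` is not yet measured; it differs from compound 1 as follows: trifluoromethyl in place of chloro on an aromatic carbon. For the measured compounds named here, no measured step tells how large this change is in this assay, so no step beyond the scatter is expected. Compound 4 is expected to give 60 ug/mL, within 30 ug/mL to 150 ug/mL. The expected step is a step that the limit leaves unreadable from compound 1 to compound 4.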

Compound 4, half-maximal cytotoxic concentration: > 50 ug/mL
Compound 4: no number, only a limit (the forecaster's own chance of this, stated with the estimate: 75%); the middle value is on the limit's open side.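

Compound 4 also gives only a limit of the assay in this assay, so its steps to compound 1, compound 2 and compound 3 cannot be read: the limit of > 50 ug/mL in this assay, at which 4 of the 4 values shown sit. The compounds shown leave open whether chloro, fluoro or trifluoromethyl makes any difference to cytotoxicity in this assay.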